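A few compounds are considered here, and "the series" means these few. Any claim that something is new, unique, unknown or untested is made for them only; others in the source may bear on it.

Compound 1 `O=c1oc2ccc(Cl)cc2c(O)c1C(c1ccc(Cl)cc1Cl)c1c(O)c2cc(Cl)ccc2oc1=O`, compound 2 `O=c1oc2ccc(Cl)cc2c(O)c1C(c1cccc([N+](=O)[O-])c1)c1c(O)c2cc(Cl)ccc2oc1=O` and compound 3 `COc1cc(C(c2c(O)c3cc(C)ccc3oc2=O)c2c(O)c3cc(C)ccc3oc2=O)cc(OC)c1OC` have all been measured in an assay on isolated protein for inhibition of Maltase-glucoamylase (Homo sapiens); on this read-out lower numbers stand for stronger inhibition and higher numbers for weaker inhibition. In this assay compound 1 gives 16500 nM, compound 2 gives 27100 nM and compound 3 gives 386000 nM. Compound 2 thus holds the second highest of the three numbers; its nearest neighbour is compound 1, and the single-place step a 1.6-fold higher number from compound 1 to compound 2 (0.22 log units; within the scatter) stays within the scatter. Among the measured compounds shown here, compound 3 differs from compound 2 in more than one place, so no single step links them, and its number stands far above that of compound 2.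

The unmeasured compound 4 `COc1ccc(C(c2c(O)c3cc(Cl)ccc3oc2=O)c2c(O)c3cc(Cl)ccc3oc2=O)cc1O` differs from compound 2 in one place: 3-hydroxy-4-methoxyphenyl in place of 3-nitrophenyl on a saturated chain carbon bound to two aromatic carbons. For the measured compounds named here, only the step from compound 1 to compound 2 bears directly on a swap at this position, and it was small. Compound 4 does carry a methoxy group on its side aryl, as compound 3 does, and compound 3 gives 386000 nM in this assay, but compound 3 also has a different core, so that comparison is loose. The expected step is a 1.5-fold higher number from compound 2 to compound 4 (0.17 log units; within the scatter), a moderate rise in the number. The estimate for compound 4 in this assay is 40000 nM, with a range from 12000 nM to 150000 nM.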

Compound 4, half-maximal inhibitory concentration: 113000 nM
Compound 4: middle estimate off by 2.8-fold (0.45 log units), on the low side; measured number inside the range.
By their numbers in this assay, from the lowest: compounds 1 and 2 (each within the scatter of the next); then compound 4; then compound 3.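

In this assay, the step of a 4.2-fold higher number from compound 2 to compound 4 (0.62 log units; beyond the scatter) lies beyond the scatter, as does the step of a 6.8-fold higher number from compound 1 to compound 4 (0.84 log units; beyond the scatter), so this position on the saturated chain carbon bound to two aromatic carbons does respond to the choice of aryl group, which the earlier swap within the scatter had not shown. On the shared core, 3-hydroxy-4-methoxyphenyl gives weaker inhibition than either 3-nitrophenyl or 2,4-dichlorophenyl, and the rise from the 3-nitrophenyl compound comes with the same count of heavy atoms and hydrogen-bond acceptors but with a hydrogen-bond donor gained. No measurement here accounts for this rise in the number.

The compounds shown do not separate the hydroxy group from the methoxy group, so it stays open whether one of them alone carries the rise or the two act only together. Also open, on these data alone, is how an amine or a carboxylic acid on this aryl ring would fare on the same core.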